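Capping the amine of a phenylthiazole sulfamide

This account rests on a few compounds, and the source may have more. Where it says the series, first, only, none or still open, it means among the compounds named here.

Measured so far in an assay for inhibition of protein deacetylase HDAC6 (Homo sapiens); a lower number here means a stronger inhibitor, a higher number a weaker inhibitor:
compound 1, `NS(=O)(=O)NCCCC[C@H](NC(=O)OCc1ccccc1)C(=O)Nc1nc2ccccc2s1`, gives 190 nM
compound 2, `COc1ccc(-c2csc(NC(=O)[C@H](CCCCNS(N)(=O)=O)NC(=O)OCc3ccccc3)n2)cc1`, gives 200 nM
compound 3, `N[C@@H](CCCCNS(N)(=O)=O)C(=O)Nc1nc(-c2ccccc2)cs1`, gives 1100 nM

Compound 3 stands at the highest number of the three, and both gaps to it lie beyond the usual scatter: compound 2 sits nearest with a clearly lower value, compound 1 furthest with a value lower still. Compound 3 is the only one of the three whose amine nitrogen carries just a hydrogen; compounds 1 and 2 both carry a carbamate cap there, and both come out as stronger inhibitors.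

Compound 4, `NS(=O)(=O)NCCCC[C@H](NC(=O)OCc1cccc(Cl)c1)C(=O)Nc1nc(-c2ccccc2)cs1`, is not yet measured. It differs from compound 3 in one place: ((3-chlorobenzyl)oxy)carbonyl in place of hydrogen on an amine nitrogen. This is the same kind of cap found in compounds 1 and 2, here with a chlorine on the ring.

Within the data shown here, since no pair of measured compounds shows this exact change, the expectation rests on the values of compounds 1 and 2 against compound 3. Because compound 1 gives 190 nM and compound 2 gives 200 nM while compound 3 gives 1100 nM, the entering group is expected to move the number downward, by a step estimated at a 5.5-fold lower number from compound 3 to compound 4 (0.74 log units; beyond the scatter), well beyond the scatter. Compound 4 is therefore expected to come in at about 200 nM, within a range of 80 nM to 500 nM.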

Compound 4, half-maximal inhibitory concentration: 280 nM
Estimate against measurement, compound 4: 1.4-fold (0.15 log units) below; the measured number falls inside the stated range.
By their numbers in this assay, from the lowest: compounds 1, 2 and 4 (each within the scatter of the next); then compound 3.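

In this assay, the cap on the amine nitrogen can now be judged on its own: with only this one place changed, ((3-chlorobenzyl)oxy)carbonyl in place of hydrogen gives a 3.9-fold lower number from compound 3 to compound 4 (0.59 log units; beyond the scatter). Until now, the link between a capped nitrogen and a stronger inhibitor rested on compounds 1 and 2, which also differ from compound 3 elsewhere in the molecule, so it could not be credited to the cap alone. This single-change pair shows that a carbamate cap carrying a chlorinated benzyl ring is enough on its own to give a step beyond the scatter on the core of compound 3. Nothing available here explains the size or direction of this step.

On these data alone, how much of the step belongs to the chlorine stays open, as the cap without it appears only in compounds 1 and 2, whose other ends differ from compound 3. Also open, as far as these compounds go, is whether the aromatic ring of the cap matters at all, a question that an acetyl group or a methyl carbamate on the same amine nitrogen could address.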